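Moving the fluorine around the benzyl ring

The source may report more compounds than this note shows. Statements on the series, on what has been measured and on what is new or still open speak of the compounds shown alone.

The two measured compounds share one core and differ in a single group on an aromatic carbon. In a functional assay on HT-29 cells (Homo sapiens) for inhibition, read by MTT assay, with a stated time of 48 h (a lower number here means a stronger inhibitor, a higher number a weaker inhibitor), compound 1 `Cc1ccc(NC(=O)NC(=O)c2ccc(OCc3ccccc3F)cc2)cc1-c1nc2ccccc2[nH]1` gives 760 nM. Compound 2 `O=C(NC(=O)c1ccc(OCc2ccccc2F)cc1)Nc1ccc(Cl)c(-c2nc3ccccc3[nH]2)c1` gives 590 nM in this assay. The step of a 1.3-fold lower number from compound 1 to compound 2 (0.11 log units; within the scatter) is within the scatter, so the two compounds stand level and neither can be called the stronger one.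

Compound 3 `O=C(NC(=O)c1ccc(OCc2ccc(F)cc2)cc1)Nc1ccc(Cl)c(-c2nc3ccccc3[nH]2)c1` keeps the chloro of compound 2 and moves the fluorine on the benzyl group: 4-fluorophenyl in place of 2-fluorophenyl on a saturated chain carbon bound to an oxygen on an aromatic ring. Going by the values given here, no measured step touches this part of the molecule; the only step on record, from compound 1 to compound 2, concerns the group on the core and was itself within the scatter. There is therefore nothing in the data pointing to a change in either direction, and the expectation is a step of about the size of the scatter or less.

On that basis compound 3 is expected to give 600 nM in this assay, with a range from 200 nM to 1800 nM, which means an expected step of a 1.0-fold higher number from compound 2 to compound 3 (0.01 log units; within the scatter).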

Compound 3, half-maximal inhibitory concentration: 730 nM
For compound 3 the middle estimate is 1.2-fold (0.09 log units) below the measured one; the range from low to high includes it.
By their numbers in this assay, from the lowest: compounds 2, 3 and 1 (each within the scatter of the next).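

Going by these compounds alone, this is the first measured step at the benzyl end of the molecule, away from the group on the core that changed between the earlier compounds. In this assay, with the chloro held in place, swapping 2-fluorobenzyl for 4-fluorobenzyl gives a step of a 1.2-fold higher number from compound 2 to compound 3 (0.09 log units; within the scatter), so these two placings of the fluorine cannot be told apart in this read-out, and the same atoms joined differently leave the number within ordinary measurement noise. Nothing available here bears on why the two compounds stand level.

Both compounds tested at this position still carry a fluorine on the benzyl ring, so the data show only that one fluorine placing matches another, not whether the fluorine or the benzyl group matters at all. Going by these compounds, a plain benzyl with no fluorine, a benzyl ring carrying an amine or a carboxylic acid, and a longer chain between the oxygen and the ring would each test this more severely, and the pairing of 4-fluorobenzyl with the methyl of compound 1 also remains open.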